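The source may report more compounds than this note shows. Statements on the series, on what has been measured and on what is new or still open speak of the compounds shown alone.

Measured in a functional assay on RAW264.7 cells (Mus musculus) for inhibition, read by Griess assay, with stated times of 1 h and 24 h; on this read-out higher numbers stand for weaker inhibition and lower numbers for stronger inhibition:

- compound 1 `O=C1CC(c2ccccc2OCc2ccc(F)cc2)Oc2ccccc21`: 28200 nM
- compound 2 `C=CCOc1ccccc1C1CC(=O)c2ccccc2O1`: 37800 nM

Compound 2, at 37800 nM, stands level with compound 1 within the scatter, so the two numbers give no ranking. Compound 3 `CCCCCOc1ccccc1C1CC(=O)c2ccccc2O1`, not yet measured, has butyl in place of vinyl on a saturated chain carbon bound to an oxygen on an aromatic ring. The same difference can be read as allyloxy to pentyloxy.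

For the measured compounds named here, one measured step bears on this change. It falls at the same place and runs a 1.3-fold higher number from compound 1 to compound 2 (0.13 log units; within the scatter). Going by the values given here, a change of group there has so far left this assay within the scatter, but this is a single step, and no measured compound carries a saturated alkyl chain at this place. No clear direction can be drawn from it, and no shift beyond the scatter is expected. The expected change is a 1.3-fold lower number from compound 2 to compound 3 (0.10 log units; within the scatter). For compound 3 the estimated value is 30000 nM, with an expected range of 14000 nM to 60000 nM.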

Compound 3, half-maximal inhibitory concentration: 39200 nM
Compound 3: middle estimate off by 1.3-fold (0.12 log units), on the low side, within the range that was stated.
By their numbers in this assay, from the lowest: compounds 1, 2 and 3 (each within the scatter of the next).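

In this assay, compound 3 brings a saturated alkyl chain to this place, which compound 1 and compound 2 lack, and butyl in place of vinyl gives a 1.0-fold higher number from compound 2 to compound 3 (0.02 log units; within the scatter) with no effect beyond the scatter. The double bond outside aromatic rings is therefore not needed to hold the number at this level, at least in the step from allyloxy to pentyloxy. Butyl in place of 4-fluorophenyl gives a 1.4-fold higher number from compound 1 to compound 3 (0.14 log units; within the scatter) as well, so 4-fluorophenyl, vinyl and butyl on a saturated chain carbon bound to an oxygen on an aromatic ring are not separated by this assay. No measurement on hand accounts for this flat reading.

Still open, as far as these compounds go, is whether a terminal amine or carboxylic acid on this chain, or a much longer chain, would move the number beyond the scatter. It is also open whether any change at this place can do so, since all three compounds shown stand within the scatter of one another.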